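The source may report more compounds than this note shows. Statements on the series, on what has been measured and on what is new or still open speak of the compounds shown alone.

Of the compounds shown here, two have so far been measured in an ADME assay for permeability, using PAMPA, at pH 7.4; on this read-out lower numbers stand for lower permeability and higher numbers for higher permeability. Compound 1 `Cc1cc(NC(=O)Nc2ccc(C)c(Cl)c2)c2ccccc2n1` gives 262 10^-6 cm/s, and compound 2 `Cc1cc(NC(=O)Nc2ccc(N)cc2)c2ccccc2n1` gives 530 10^-6 cm/s, the highest of the two numbers; compound 1 is the nearest, with a lower number by a gap beyond the usual scatter.

Compound 3 `CCc1ccc(NC(=O)Nc2cc(C)nc3ccccc23)cc1` differs from compound 2 in one place: ethyl in place of amino on an aromatic carbon. Among the compounds with values here, no step between measured compounds shows what this change does, so the step in this assay is expected to be small, likely within the scatter, in either direction. Compound 3 is therefore expected to give about 450 10^-6 cm/s in this assay, between 220 10^-6 cm/s and 850 10^-6 cm/s. The expected step is a 1.2-fold lower number from compound 2 to compound 3 (0.07 log units; within the scatter).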

Compound 3, apparent permeability: 535 10^-6 cm/s
Estimate against measurement, compound 3: 1.2-fold (0.08 log units) below; the measured number falls inside the stated range.
By their numbers in this assay, from the lowest: compound 1; then compounds 2 and 3 (each within the scatter of the next).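

In this assay, ethyl in place of amino on this aromatic carbon, para to a large group, gives a 1.0-fold higher number from compound 2 to compound 3 (0.00 log units; within the scatter) and so leaves the read-out level within the scatter. This pair shows that the amino, with its hydrogen-bond donor and acceptor, can give way here to an ethyl, which has neither, with no measurable change. Nothing measured here explains this result.

On these data alone, what a carboxylic acid or a longer chain at this place would do remains open. A single pair also cannot show whether other groups here would behave the same way.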